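Dichlorophenyl for methoxyphenyl on the piperazine nitrogen

The source may hold more compounds than are shown below. What is called first, only, known or untested is meant among the compounds shown, and "the series" means these compounds.

Measured compounds:
compound 1, `O=C(CN1CCN(c2ccccc2)CC1)N(c1ccccc1)c1ccccc1`, 27 mg/kg
compound 2, `COc1ccccc1N1CCN(CC(=O)N(c2ccccc2)c2ccccc2)CC1`, 12.7 mg/kg
compound 3, `COc1cccc(N2CCN(CC(=O)N(c3ccccc3)c3ccccc3)CC2)c1`, 15.5 mg/kg

Of the compounds shown here, three have been tested in a functional assay on the whole organism (strain Swiss albino) for inhibition, with Mus musculus as the target, with stated times of 30 min, 10 min and 20 min; a lower number here means that less compound is needed, a higher number that more compound is needed for the effect. Compound 3 `COc1cccc(N2CCN(CC(=O)N(c3ccccc3)c3ccccc3)CC2)c1` gives 15.5 mg/kg in this assay, the second highest of the three numbers; its nearest neighbour is compound 2 and its furthest is compound 1, and both gaps are within the scatter. The measured steps are a 2.1-fold lower number from compound 1 to compound 2 (0.33 log units; beyond the scatter), a 1.7-fold lower number from compound 1 to compound 3 (0.24 log units; within the scatter) and a 1.2-fold higher number from compound 2 to compound 3 (0.09 log units; within the scatter); only the first reaches beyond the scatter, and all three concern a methoxy group.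

Compound 4 `O=C(CN1CCN(c2ccc(Cl)c(Cl)c2)CC1)N(c1ccccc1)c1ccccc1` differs from compound 3 as follows: 3,4-dichlorophenyl in place of 3-methoxyphenyl on an amine nitrogen in a ring. Within the data shown here, no measured step involves chlorine, so nothing among the three compounds speaks directly to this change. The steps that exist show that swapping groups on this ring nitrogen moved this assay only modestly. Compound 4 is therefore expected to stay near compound 3, with the estimated step of a 1.0-fold lower number from compound 3 to compound 4 (0.01 log units; within the scatter) lying within the scatter. The estimate for compound 4 in this assay is 15 mg/kg, in a range from 7 mg/kg to 35 mg/kg.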

Compound 4, dose for half-maximal effect: > 20 mg/kg
Compound 4: only a limit was reported; the forecaster's own chance of this, stated with the estimate: 5%; middle value at least 1.3-fold (0.12 log units) from the limit.
By their numbers in this assay, from the lowest: compounds 2, 3 and 1 (each within the scatter of the next, the first and the last beyond it).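

In this assay, compound 4, with 3,4-dichlorophenyl on the amine nitrogen in the ring, has a limit and not a number: the limit of > 20 mg/kg in this assay, at which 1 of the 4 values shown sits. Against the two methoxy compounds, the record shows an at least 1.2-fold higher number from compound 3 to compound 4 (0.11 log units; that floor lies within the scatter) and an at least 1.5-fold higher number from compound 2 to compound 4 (0.19 log units; that floor lies within the scatter). Chlorine on this ring therefore gives the first compound here without an exact value, and neither floor separates it from the methoxy compounds, while the step from compound 1 to compound 4 cannot be read.

The compounds shown leave open how large the true gap is for compound 4. They also leave open whether a single chlorine, a fluorine or a trifluoromethyl group on this ring would give a readable number and so separate the effect of the two chlorines.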